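A few compounds are considered here, and "the series" means these few. Any claim that something is new, unique, unknown or untested is made for them only; others in the source may bear on it.

Compounds measured in a functional assay on HeLa cells (Homo sapiens) for inhibition, read by MTT assay, with a stated time of 72 h; on this read-out higher numbers stand for weaker inhibition and lower numbers for stronger inhibition:

compound 1, `CN(C(=O)NC(=O)c1ccc(Cl)cc1Cl)c1nc(C(F)(F)F)c(C(=O)N/N=C/c2ccc(C(F)(F)F)cc2)s1`, 7.99 ug/mL
compound 2, `CN(C(=O)NC(=O)c1ccc(F)c(F)c1)c1nc(C(F)(F)F)c(C(=O)N/N=C/c2ccc([N+](=O)[O-])cc2)s1`, 5.08 ug/mL
compound 3, `Cc1nc(N(C)C(=O)NC(=O)c2ccc(Cl)cc2Cl)sc1C(=O)N/N=C/c1ccc(C(F)(F)F)cc1`, 20.3 ug/mL

Compound 1 stands second highest of the three numbers. Compound 2 lies at a lower number, and this assay places the two within the usual scatter, so no order between compound 1 and compound 2 can be read. Within the data shown here, compound 3 gives a higher number; the only single-place step among the measured compounds is a 2.5-fold higher number from compound 1 to compound 3 (0.40 log units; beyond the scatter), where methyl replaces trifluoromethyl on an aromatic carbon of the shared core.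

Compound 4, `CN(C(=O)NC(=O)c1c(F)cccc1F)c1nc(C(F)(F)F)c(C(=O)N/N=C/c2ccc(C(F)(F)F)cc2)s1`, differs from compound 1 in one place: 2,6-difluorophenyl in place of 2,4-dichlorophenyl on a carbonyl carbon. Among the measured compounds shown here, no measured step touches this part of the molecule. Compound 2 also carries a difluorophenyl on that carbonyl carbon, but it differs from compound 1 in a second place as well, so only its value can be set beside that of compound 1, and the two lie within the scatter. The step in this assay from compound 1 to compound 4 is therefore expected to be small, a 1.0-fold higher number from compound 1 to compound 4 (0.00 log units; within the scatter), with no clear direction. Compound 4 is estimated at 8 ug/mL, in a range from 3 ug/mL to 20 ug/mL.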

Compound 4, half-maximal inhibitory concentration: 30.6 ug/mL
For compound 4 the middle estimate is 3.8-fold (0.58 log units) below the measured one; the measured number lies above the stated range.
By their numbers in this assay, from the lowest: compounds 2 and 1 (each within the scatter of the next); then compounds 3 and 4 (each within the scatter of the next).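

Among these compounds, this is the first measured change to the aromatic group on this carbonyl carbon, and in this assay replacing 2,4-dichlorophenyl with 2,6-difluorophenyl is not neutral: it gives a 3.8-fold higher number from compound 1 to compound 4 (0.58 log units; beyond the scatter). Among the compounds shown here, the two groups match in what is counted for them, including heavy atoms and hydrogen-bond donors and acceptors, yet the single step changes both the kind of halogen and where it sits on the ring, so these two changes cannot be separated. No measurement here explains the step.

The compounds shown leave open whether 2,6-dichlorophenyl or 2,4-difluorophenyl would follow the halogen or its placement. They also leave open how plain phenyl, with no halogen, or a ring carrying an amine or a carboxylic acid would read out at this carbonyl carbon.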